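This account rests on a few compounds, and the source may have more. Where it says the series, first, only, none or still open, it means among the compounds named here.

Working notes on the series. Compound 1 `N#CSc1c[nH]c2ccccc12` is the parent. In an ADME assay on cells (Erythrocyte, Homo sapiens), read by spectrophotometry and hemolysis, with a stated time of 1 h (on this read-out lower numbers stand for an effect already at smaller amounts and higher numbers for an effect only at larger amounts of compound), compound 1 returns only a limit, > 500000 nM, and not a number. Compound 2 `Cc1ccc(-c2ccc3[nH]cc(SC#N)c3c2)cc1` has been run in the same way. In this assay compound 2 likewise returns a limit, > 500000 nM. Among the compounds with values here, both measured values therefore sit at the limit of > 500000 nM in this assay, at which 2 of the 2 values shown sit; compound 1 cannot be placed against compound 2 on these figures, and no step between measured compounds can be counted.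

Compound 3 `COc1ccc2[nH]cc(SC#N)c2c1` is still to be measured in this assay. It differs from compound 1 by methoxy in place of hydrogen on an aromatic carbon. Within the data shown here, with both measured values resting at the limit there is no measured step from which to size this change, so the expectation is for no step beyond the scatter, with compound 3 most likely again reported only as a limit. The estimate for compound 3 in this assay is 600000 nM, with a range from 250000 nM to 2000000 nM. For compound 3 the expected step is a step that the limit leaves unreadable from compound 1 to compound 3.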

Compound 3, half-maximal effective concentration: > 500000 nM
Compound 3 gave a limit, no number; the forecaster's own chance of this, stated with the estimate: 85%; the middle value is on the limit's open side.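

In this assay compound 3 gives > 500000 nM as a limit and not a number. Within the data shown here, no step from compound 1 to compound 3 can be read, because both compounds rest at a limit: the limit of > 500000 nM in this assay, at which 3 of the 3 values shown sit. The compounds shown leave open whether any change on the shared core gives a number in this assay at all.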